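Widening the Ring on an Amide Nitrogen

This account rests on a few compounds, and the source may have more. Where it says the series, first, only, none or still open, it means among the compounds named here.

Of the compounds shown here, two sharing one core have been measured in an assay on HEK293 cells for displacement of a labelled ligand from adenosine receptor A2b (Homo sapiens), read by scintillation counting, with a stated time of 30 min, tested at 10 uM; on this read-out higher numbers stand for more inhibition at the one concentration tested (going by the name of the read-out) and lower numbers for less inhibition. Compound 1, `COc1cccc2cc(C(=O)NCC(O)CO)c(=O)oc12`, carries a short open chain with hydroxyl groups on its amide nitrogen, and in this assay compound 1 gives 25%. Compound 2, `COc1cccc2cc(C(=O)NC3CCCC3)c(=N)oc12`, carries a cyclopentyl group on that nitrogen and an imine in place of the carbonyl of compound 1; in this assay compound 2 gives 47%, the higher of the two numbers, and its gap to compound 1 is wider than the usual scatter.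

Compound 3, `COc1cccc2cc(C(=O)NC3CCCCC3)c(=N)oc12`, is the untested partner of compound 2. For the measured compounds named here, the only change is cyclohexyl in place of cyclopentyl on an amide-type nitrogen. Going by the values given here, since the two differ in just that ring and no comparable pair has been measured, only a modest shift is expected: the step from compound 2 to compound 3 in this assay is estimated as a number 3 percentage points higher from compound 2 to compound 3 (within the scatter), a change not clearly beyond the scatter. Compound 3 is therefore expected to give about 50% in this assay, most likely between 32% and 68%.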

Compound 3, a percentage reported as inhibition, at one concentration (the size of the read-out at that concentration, not a potency): > 70%
Compound 3 ended at the assay's limit; the forecaster's own chance of this, stated with the estimate: 0%; middle value at least 20 percentage points from the limit.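

Cyclohexyl in place of cyclopentyl on the amide-type nitrogen gives, in this assay, a number at least 23 percentage points higher from compound 2 to compound 3 (beyond the scatter). Compound 1 and compound 2 differ in two places, so their gap could not be tied to either one, whereas this pair differs only in the ring, which shows that the group on this nitrogen can by itself shift the read-out beyond the scatter, even when the change is as small as going from a five-membered to a six-membered carbon ring. The reading of > 70% for compound 3 is a limit of the assay and not a number, so the step has a floor but no known size: the limit of > 70% in this assay, at which 1 of the 3 values shown sits.

As far as these compounds go, whether the gain continues with a still larger ring such as cycloheptyl, or holds with a phenyl ring or an open hexyl chain on the same nitrogen, stays open. Also open, from the compounds shown here alone, is how much the imine contributes, a question that a partner of compound 3 with a carbonyl in place of the imine would address, since that would change one place only.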